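Cyano replacing methoxyphenyl on the sulfonyl aryl ring

The source may report more compounds than this note shows. Statements on the series, on what has been measured and on what is new or still open speak of the compounds shown alone.

Measured compounds:
compound 1, `CC1CCN(C2CCN(S(=O)(=O)c3cccc4cnccc34)CC2)CC1`: 225 nM
compound 2, `COc1ccccc1-c1ccc(S(=O)(=O)N2CCC(N3CCC(C)CC3)CC2)cc1`: 26 nM
compound 3, `COc1ccc(Br)cc1S(=O)(=O)N1CCC(N2CCC(C)CC2)CC1`: 2 nM

In a functional assay on DLD-1 cells (Homo sapiens) for antiproliferative activity, read by CellTiter-Glo, with a stated time of 72 h (on this read-out lower numbers stand for stronger inhibition and higher numbers for weaker inhibition), compound 2 gives 26 nM, the second highest of the three numbers. Compound 1 gives 225 nM, a higher number that lies beyond the scatter, while compound 3 gives 2 nM, a lower number also beyond the scatter. Compound 4, `CC1CCN(C2CCN(S(=O)(=O)c3ccc(C#N)cc3)CC2)CC1`, has not yet been measured in this assay. Among the compounds with values here, it differs from compound 2 at one place: cyano in place of 2-methoxyphenyl on an aromatic carbon The cyano group is far smaller than the 2-methoxyphenyl it replaces, and no measured pair shows this change directly. A weakening beyond the scatter is expected, so that the step of a 5.8-fold higher number from compound 2 to compound 4 (0.76 log units; beyond the scatter) points toward a higher number. Compound 4 is estimated at 150 nM in this assay, within a range from 40 nM to 600 nM.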

Compound 4, half-maximal inhibitory concentration: 2800 nM
Estimate against measurement, compound 4: 19-fold (1.27 log units) below; measured number outside the range, above it.
By their numbers in this assay, from the lowest: compound 3; then compound 2; then compound 1; then compound 4.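

In this assay the exchange of 2-methoxyphenyl for cyano, para to a large group, gives a 110-fold higher number from compound 2 to compound 4 (2.03 log units; beyond the scatter) and so costs a very large amount of activity at this position. Within the data shown here, the earlier compounds held no pair differing in one place, so this is the first direct reading of a change here. Nothing measured explains the size of this step.

On these data alone, how an unsubstituted phenyl ring or a small amine would read at this place remains open. The compounds shown therefore do not separate the loss of the 2-methoxyphenyl ring from the entry of cyano.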